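Swapping a Chain for a Ring on the Shared Core

The compounds below may be only part of what the source reports. "The series", "measured", "known", "first", "only" and "open" are said of these compounds alone.

Among the measured compounds shown here, in a functional assay on LNCaP cells (Homo sapiens) for cytotoxicity, read by MTT assay, with a stated time of 72 h (a higher number here means a weaker inhibitor, a lower number a stronger inhibitor), compound 1 (`Nc1cccc(Nc2c(C(=O)NCc3ccc(F)cc3)nc(Br)c3cccnc23)c1`) gives 8000 nM, the only number available so far. Compound 2 (`NCCCNc1c(C(=O)NCc2ccc(F)cc2)nc(Br)c2cccnc12`) has no such number, and its result stands as "not determined" (no result reported). It therefore cannot be ranked as stronger or weaker than anything else, and it offers no starting value for the next comparison. Compound 3 (`Nc1ccc(Nc2c(C(=O)NCc3ccc(F)cc3)nc(Br)c3cccnc23)cc1`) has 4-aminophenyl in place of 3-aminopropyl on a nitrogen on an aromatic ring. For the measured compounds named here, with no measured step to guide the size of this change, the single anchor is compound 1 at 8000 nM. Compared with that value, no shift beyond the usual scatter is expected in this assay, in either direction, though the evidence is thin. Compound 3 is estimated at 7000 nM, with an expected range of 2000 nM to 25000 nM.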

Compound 3, half-maximal inhibitory concentration: 7000 nM
For compound 3 middle estimate and measured number coincide at the digits printed; the measured number falls inside the stated range.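

In this assay, among the compounds shown here, putting 4-aminophenyl in place of 3-aminophenyl on the nitrogen gives a 1.1-fold lower number from compound 1 to compound 3 (0.06 log units; within the scatter), the first step that can be read at this position. Compound 1 and compound 3 therefore cannot be told apart here, so for this pair the placement of the amine on the phenyl ring does not register in the read-out. No measurement shown here accounts for this result.

On these data alone, the step from compound 2 to compound 3 cannot be read, so how the 3-aminopropyl chain compares with either aminophenyl group stays unknown. As far as these compounds go, it also remains open whether a hydroxyl group or a carboxylic acid in place of the amine on the phenyl ring would separate from these two values.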